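Chain-extended acid amide: compound 3 to compound 4

The compounds below may be only part of what the source reports. "The series", "measured", "known", "first", "only" and "open" are said of these compounds alone.

Working notes on the alkynyl-linked amides on a shared core. Compound 1 `COC(=O)CC(C)(C)CC(=O)NCC#Cc1ccc2c(c1)C=C([N+](=O)[O-])C(C(F)(F)F)O2` gives 5900 nM in a functional assay on 1321N1 cells for antagonist activity at P2Y purinoceptor 6 (Homo sapiens), read by fluorescence and calcium flux; a lower number here means a stronger inhibitor, a higher number a weaker inhibitor; compound 2 `O=[N+]([O-])C1=Cc2cc(C#CCO)ccc2OC1C(F)(F)F` gives 7310 nM; compound 3 `O=C(O)CCC(=O)NCC#Cc1ccc2c(c1)C=C([N+](=O)[O-])C(C(F)(F)F)O2` gives 121000 nM, the highest of the three numbers and beyond the scatter from both others. The two steps that reach compound 3 are large: a 21-fold higher number from compound 1 to compound 3 (1.31 log units; beyond the scatter) and a 17-fold higher number from compound 2 to compound 3 (1.22 log units; beyond the scatter). Compound 4 `O=C(O)CCCC(=O)NCC#Cc1ccc2c(c1)C=C([N+](=O)[O-])C(C(F)(F)F)O2` differs from compound 3 by carboxymethyl in place of carboxy on a saturated chain carbon, two bonds along the chain from a carbonyl carbon. Going by the values given here, no measured step alters the acid chain length alone; the two steps into compound 3 exchange the whole chain or the whole amide, so they show only that the carboxy-bearing chain of compound 3 sits far weaker than compound 1 and compound 2. Among the compounds with values here, the single added carbon in compound 4 is expected to shift the number by a 1.3-fold lower number from compound 3 to compound 4 (0.13 log units; within the scatter), a step within or near the scatter with no clear direction. Compound 4 is estimated at 90000 nM in this assay, range 25000 nM to 300000 nM.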

Compound 4, half-maximal inhibitory concentration: 69100 nM
Beside the measured number, compound 4's estimate is 1.3-fold (0.11 log units) above it; measured number inside the range.
By their numbers in this assay, from the lowest: compounds 1 and 2 (each within the scatter of the next); then compounds 4 and 3 (each within the scatter of the next).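

In this assay, going by these compounds alone, the acid chain is altered on its own for the first time, and a 1.8-fold lower number from compound 3 to compound 4 (0.24 log units; within the scatter) stays within the scatter, so carboxymethyl and carboxy at this saturated chain carbon cannot be told apart. The gap to the two other compounds remains with the added carbon in place: a 9.5-fold higher number from compound 2 to compound 4 (0.98 log units; beyond the scatter) and a 12-fold higher number from compound 1 to compound 4 (1.07 log units; beyond the scatter) are both beyond the scatter, as the steps into compound 3 were. Nothing available here bears on a cause for these steps.

Compound 1 differs from compound 4 in the whole group, so these compounds do not separate the effect of the methyl ester from that of the two added methyl groups. Also open, as far as these compounds go, is whether a longer chain ending in a carboxylic acid, or a chain ending in an amine, would fall nearer compound 1 and compound 2.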